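Chloro in Place of Hydrogen on a Purine-Like Core

The compounds below may be only part of what the source reports. "The series", "measured", "known", "first", "only" and "open" are said of these compounds alone.

Measured compounds:
Compound 1, `CCCCC(CCO)n1cnc2c(Cl)ncnc21`: > 50000 nM
Compound 2, `CCCCC(CCO)n1cnc2c(Cl)nc(Cl)nc21`: 30900 nM
Compound 3, `CCCCCC(CCO)n1cnc2c(N)ncnc21`: > 50000 nM

In a functional assay on SW480 cells (Homo sapiens) for antiproliferative activity, read by MTT assay, with a stated time of 48 h (on this read-out higher numbers stand for weaker inhibition and lower numbers for stronger inhibition), compound 1 reaches only the limit of the assay, > 50000 nM, and gives no number. Compound 2 differs from it by chloro in place of hydrogen on an aromatic carbon. In this assay compound 2 gives 30900 nM. The step between them is an at least 1.6-fold lower number from compound 1 to compound 2 (0.20 log units; that floor lies within the scatter).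

Compound 3 carries a core that differs from that of compound 1; how the two cores differ is not broken down here. In this assay compound 3 sits at the limit of the assay, > 50000 nM, which is not a number. Two of the three measured values sit at this limit, (the limit of > 50000 nM in this assay, at which 2 of the 3 values shown sit).

Compound 4, `CCCCCC(CCO)n1cnc2c(N)nc(Cl)nc21`, is not yet measured. It differs from compound 3 by chloro in place of hydrogen on an aromatic carbon. This is the same kind of change as the one from compound 1 to compound 2, and it occurs twice among the compounds shown, but the place is not identical: in compound 2 the entering chloro is meta to a chloro group, in compound 4 it is meta to an amino group.

The expectation for compound 4 rests on the step of an at least 1.6-fold lower number from compound 1 to compound 2 (0.20 log units; that floor lies within the scatter), whose floor lies within the scatter, so no large gain is expected. In this assay compound 4 is estimated to give about 40000 nM. The expected range runs from 15000 nM to 100000 nM. The expected step is an at least 1.2-fold lower number from compound 3 to compound 4 (0.09 log units; that floor lies within the scatter).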

Compound 4, half-maximal inhibitory concentration: > 50000 nM
Compound 4: no number, only a limit (the forecaster's own chance of this, stated with the estimate: 55%); middle value at least 1.2-fold (0.09 log units) away from the limit.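

In this assay, compound 3 and compound 4 both sit at the limit of the assay and give no number, so no step can be read between them: the limit of > 50000 nM in this assay, at which 3 of the 4 values shown sit.

The compounds shown leave open whether chloro in place of hydrogen on an aromatic carbon changes the antiproliferative activity of compound 3 at all, since any change would stay hidden behind that limit.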